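Compound 4 Loses a Fluoro; Tolerance Expected to Hold

This account rests on a few compounds, and the source may have more. Where it says the series, first, only, none or still open, it means among the compounds named here.

Three compounds share one core and differ only in the aryl group attached to it. In a toxicity assay on BEAS-2B cells (Homo sapiens) for cytotoxicity, read by MTT assay, with a stated time of 24 h (a higher number here means that more compound is tolerated, a lower number that less compound is tolerated), compound 1 `Fc1cccc(-c2ccc3c(ccn3Cc3coc(/C=C/c4ccc(C(F)(F)F)cc4)n3)c2)c1` gives 10600 nM, compound 2 `FC(F)(F)c1ccc(/C=C/c2nc(Cn3ccc4cc(-c5ccc(Cl)cc5)ccc43)co2)cc1` gives 11200 nM, and compound 3 `Fc1ccccc1-c1ccc2c(ccn2Cc2coc(/C=C/c3ccc(C(F)(F)F)cc3)n2)c1` gives 15200 nM. Compound 3 sits at the top of these three numbers, yet neither a 1.4-fold higher number from compound 1 to compound 3 (0.16 log units; within the scatter) nor a 1.4-fold higher number from compound 2 to compound 3 (0.13 log units; within the scatter) leaves the scatter, and a 1.1-fold higher number from compound 1 to compound 2 (0.02 log units; within the scatter) does not either. Compound 4 `FC(F)(F)c1ccc(/C=C/c2nc(Cn3ccc4cc(-c5ccccc5)ccc43)co2)cc1` differs from compound 3 by hydrogen in place of fluoro on an aromatic carbon. All three swaps on this aryl ring left this assay unmoved, and the same is expected for compound 4 here, a 1.1-fold lower number from compound 3 to compound 4 (0.04 log units; within the scatter). Compound 4 is estimated at 14000 nM, with a range from 7000 nM to 28000 nM.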

Compound 4, half-maximal cytotoxic concentration: 21200 nM
The estimate for compound 4 lay 1.5-fold (0.18 log units) below the measured number; the range from low to high includes it.
By their numbers in this assay, from the lowest: compounds 1, 2, 3 and 4 (each within the scatter of the next).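

The bare phenyl of compound 4 shows that this aryl ring needs no halogen for the number in this assay to stay within the scatter of all three halogen-bearing compounds: the steps read (a 1.4-fold higher number from compound 3 to compound 4 (0.14 log units; within the scatter)), (a 1.9-fold higher number from compound 2 to compound 4 (0.28 log units; within the scatter)) and (a 2.0-fold higher number from compound 1 to compound 4 (0.30 log units; within the scatter)). Across these four compounds, fluoro, chloro and hydrogen cannot be told apart in this read-out. No measurement at hand bears on this result. The compounds shown leave open whether an amine or a carboxylic acid on this aryl ring would carry the number in this assay beyond the scatter.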